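A few compounds are considered here, and "the series" means these few. Any claim that something is new, unique, unknown or untested is made for them only; others in the source may bear on it.

Measured compounds:
Compound 1 `Sc1nncc2cncn12`: in a functional assay for inhibition, with Homo sapiens as the target (a lower number here means a stronger inhibitor, a higher number a weaker inhibitor), compound 1 gives only a limit, > 48000 nM.
Compound 2 `COCc1nc(C)c2cnnc(S)n12`: in this assay compound 2 gives only a limit, > 48000 nM.
Compound 3 `Cc1ncn2c(O)nncc12`: in this assay compound 3 gives only a limit, > 48000 nM.

Compound 3 stands with no number of its own in this assay, only a limit, and the same holds for the two other compounds shown; (the limit of > 48000 nM in this assay, at which 3 of the 3 values shown sit). For the measured compounds named here, no pair of measured compounds differing in one place exists in this set, so no measured size of change is available to guide an expectation.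

Compound 4 `Cc1ncn2c(S)nncc12` differs from compound 3 by sulfanyl in place of hydroxy on an aromatic carbon. Compound 2 also carries a sulfanyl group and likewise sits at the limit in this assay, which gives no sign that this group by itself brings the read-out into the measurable range.

The step that the limit leaves unreadable from compound 3 to compound 4 is expected to be none beyond the scatter, in the sense that compound 4 is expected to remain at or beyond the limit. The estimate for compound 4 is 100000 nM, with a range from 40000 nM to 300000 nM, and it is expected that the assay will most likely again report only a limit rather than a number.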

Compound 4, half-maximal inhibitory concentration: > 48000 nM
Compound 4: only a limit was reported; the forecaster's own chance of this, stated with the estimate: 85%; the middle value lies beyond the limit too.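

No step to compound 4 from compound 1, compound 2 or compound 3 can be read in this assay, since all four compounds give only a limit there: the limit of > 48000 nM in this assay, at which 4 of the 4 values shown sit.

The compounds shown leave open whether any change on the shared core yields a measured number in this assay, and how large any of these steps would be.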